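Removing a Chloro Group from a Chalcone-Type Growth Inhibitor

The source may report more compounds than this note shows. Statements on the series, on what has been measured and on what is new or still open speak of the compounds shown alone.

Of the compounds shown here, two have been measured in a functional assay on SN12C cells (Homo sapiens) for inhibition; on this read-out lower numbers stand for stronger inhibition of growth and higher numbers for weaker inhibition of growth. Compound 1, `COc1cc(/C=C/C(=O)c2cccc(-n3cc(-c4ccc(Cl)cc4)[nH]c3=O)c2)cc(OC)c1OC`, gives 5140 nM in this assay. Compound 2, `O=C(/C=C/c1cccc(O)c1)c1cccc(-n2cc(-c3ccc(Cl)cc3)[nH]c2=O)c1`, gives 1950 nM in this assay. Of the two numbers, compound 1 stands at the higher one, and the gap to compound 2 lies beyond the scatter, so compound 2 inhibits growth more strongly than compound 1. The two compounds differ in more than one place, so nothing is attributed to any single change between them.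

Compound 3, `COc1cc(/C=C/C(=O)c2cccc(-n3cc(-c4ccccc4)[nH]c3=O)c2)cc(OC)c1OC`, has not yet been measured in this assay. It differs from compound 1 in one place only: hydrogen in place of chloro on an aromatic carbon. The chloro group sits on an aromatic carbon of a six-membered aromatic ring of carbon only, and in compound 3 a hydrogen stands there instead.

Within the data shown here, no measured pair shows what this exact change does here. The expected step from compound 1 to compound 3 is a 1.4-fold higher number from compound 1 to compound 3 (0.13 log units; within the scatter), a small move toward weaker inhibition that may not pass beyond the scatter. Compound 3 is therefore estimated at 7000 nM in this assay, within a range from 2500 nM to 20000 nM.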

Compound 3, concentration for 50% growth inhibition: 2090 nM
For compound 3 the middle estimate is 3.3-fold (0.52 log units) above the measured one; the measured number lies below the stated range.
By their numbers in this assay, from the lowest: compounds 2 and 3 (each within the scatter of the next); then compound 1.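

In this assay the change from 4-chlorophenyl to phenyl brings a 2.5-fold lower number from compound 1 to compound 3 (0.39 log units; beyond the scatter) and so moves compound 3 modestly toward stronger inhibition of growth. Compound 1 and compound 2 both carry the chloro group, so they could say nothing about this position, whereas this pair shows that on the core of compound 1 the chloro group is not needed for inhibition of growth and that the compound does better with a plain hydrogen on that aromatic carbon. The data give no measured property that would explain why the number falls when the chloro group leaves.

Going by these compounds, this is a single pair in a single assay, so it remains open whether the same change would shift the number in the same direction in compound 2, which differs from compound 1 at the other end of the molecule. On these data alone, it also remains open how a fluoro group, a methoxy group or an amine on that same aromatic carbon would compare with hydrogen and chloro.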